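The source may hold more compounds than are shown below. What is called first, only, known or untested is meant among the compounds shown, and "the series" means these compounds.

Within the data shown here, in a functional assay on brain (Rattus norvegicus, strain Wistar) for inhibition (on this read-out lower numbers stand for stronger inhibition and higher numbers for weaker inhibition), compound 1 `CCCc1ccc(-c2c(C)[nH]c(=O)n2C)cc1` gives 21500 nM, and compound 2 `CCCCCCc1ccc(-c2c(C)[nH]c(=O)n2C)cc1` gives 9000 nM, the lower of the two numbers so far. Compound 3 `Cc1[nH]c(=O)n(C)c1-c1ccc(-c2ccccc2)cc1` keeps the shared core and departs from compound 2 at one place: phenyl in place of hexyl on an aromatic carbon. Among the measured compounds shown here, only one measured step bears on this, a 2.4-fold lower number from compound 1 to compound 2 (0.38 log units; beyond the scatter), a modest change that lengthens a saturated chain. For the measured compounds named here, that step leading to compound 2 gives only indirect guidance, since no measured compound carries an aromatic ring at this place. From the compounds shown here alone, the direction of any change therefore remains open, and no step beyond the scatter is expected. The estimate is a 1.2-fold higher number from compound 2 to compound 3 (0.09 log units; within the scatter). In this assay, compound 3 is expected at 11000 nM, with an estimated range of 3500 nM to 30000 nM.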

Compound 3, half-maximal inhibitory concentration: 6300 nM
For compound 3 the middle estimate is 1.7-fold (0.24 log units) above the measured one; low and high end bracket the measured number.
By their numbers in this assay, from the lowest: compounds 3 and 2 (each within the scatter of the next); then compound 1.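

At this position, on an aromatic carbon of the six-membered aromatic ring, a saturated chain is not needed to keep the number in this assay where it stands. Putting phenyl in place of hexyl gives a 1.4-fold lower number from compound 2 to compound 3 (0.15 log units; within the scatter) and so stays within the scatter, which means a ring and a chain with the same count of heavy atoms cannot be told apart here. Against the shorter propyl, the phenyl group gives a 3.4-fold lower number from compound 1 to compound 3 (0.53 log units; beyond the scatter) and this modest step lies beyond the scatter, so hexyl and phenyl both stand apart from propyl.

From the compounds shown here alone, whether an amine, a carboxylic acid or a chain longer than hexyl at this place would move the number further stays open. Nothing at hand gives a reason for these numbers.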